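Chloro for trifluoromethyl on the urea aryl ring

The source may report more compounds than this note shows. Statements on the series, on what has been measured and on what is new or still open speak of the compounds shown alone.

The two measured compounds are diaryl ureas on a shared core. Compound 1 `O=C(Nc1cccc(-n2cc(-c3ccncc3)c(-c3cc(O)cc(Cl)c3)n2)c1)Nc1ccc(Cl)c(Cl)c1` gives 104% in a functional assay on RPMI-8226 cells (Homo sapiens) for inhibition, read by sulforhodamine B assay, with a stated time of 48 h, tested at 0.01 uM; a higher number here means a weaker effect of the compound at the concentration tested, a lower number a stronger effect. Compound 2 `COc1cc(Cl)cc(-c2nn(-c3cccc(NC(=O)Nc4ccc(Cl)c(C(F)(F)F)c4)c3)cc2-c2ccncc2)c1` gives 97% in this assay. Of the two numbers shown, that of compound 2 is the smaller, but its gap to compound 1 lies within the usual scatter, so the two compounds cannot be told apart on these data.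

Compound 3 `COc1cc(Cl)cc(-c2nn(-c3cccc(NC(=O)Nc4ccc(Cl)c(Cl)c4)c3)cc2-c2ccncc2)c1` differs from compound 2 in one place: chloro in place of trifluoromethyl on an aromatic carbon. Among the compounds with values here, no measured pair shows this change directly. Compound 3 shares its 3,4-dichlorophenyl group with compound 1, and in this assay compound 1 gives 104%, so no step beyond the scatter is expected. The step is estimated as a number 3 percentage points higher from compound 2 to compound 3 (within the scatter). Compound 3 is therefore expected to give about 100%, with a likely range from 88% to 112%.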

Compound 3, a percentage reported as activity, at one concentration (the size of the read-out at that concentration, not a potency): 99%
For compound 3 the middle estimate is 1 percentage points above the measured one, within the range that was stated.
By their numbers in this assay, from the lowest: compounds 2, 3 and 1 (each within the scatter of the next).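

Within the data shown here, compound 3 gives the first direct reading of chloro in place of trifluoromethyl at this position, ortho to a chloro group: in this assay the step of a number 2 percentage points higher from compound 2 to compound 3 (within the scatter) means that the two groups cannot be told apart on this ring at the concentration tested. Compound 3 also links the two earlier compounds through a single change, methyl in place of hydrogen on an oxygen on an aromatic ring, and the step of a number 5 percentage points lower from compound 1 to compound 3 (within the scatter) leaves that change unresolved as well. No accompanying measurement bears on either step.

On these data alone, all three compounds lie within the scatter of one another at a single concentration, so it remains open whether either position can shift this read-out at all. Also open, as far as these compounds go, is whether an amine or a carboxylic acid in place of the trifluoromethyl would give a different reading.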